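The source may hold more compounds than are shown below. What is called first, only, known or untested is meant among the compounds shown, and "the series" means these compounds.

Compound 1, `O=C(/C=C/c1ccc(OCCCCO[N+](=O)[O-])c(O)c1)OCCCCO[N+](=O)[O-]`, gives > 50000 nM in a functional assay on NCI-H1792 cells (Homo sapiens) for cytotoxicity, read by resazurin assay, with a stated time of 72 h; a lower number here means a stronger inhibitor, a higher number a weaker inhibitor; that figure is a limit of the assay, not a number.
Compound 2, `O=C(/C=C/c1ccc(O)c(O)c1)OCc1c(-c2ccccc2)no[n+]1[O-]`, gives 3780 nM in this assay.
Compound 3, `COc1cc(/C=C/C(=O)OCc2c(-c3ccccc3)no[n+]2[O-])ccc1O`, gives 11100 nM in this assay.

Compound 2 and compound 3 share one core and differ in a single place: methyl in place of hydrogen on an oxygen on an aromatic ring. That change made a 2.9-fold higher number from compound 2 to compound 3 (0.47 log units; beyond the scatter), so the methylated compound 3 is the weaker of the pair in this assay.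

Compound 1 is built on a different core; how the two cores differ is not broken down here. Of compound 1 only a limit is known, since it sits at the limit of > 50000 nM in this assay, at which 1 of the 3 values shown sits.

Compound 4, `COc1cc(/C=C/C(=O)OCCCCO[N+](=O)[O-])ccc1OCCCCO[N+](=O)[O-]`, has not yet been measured. It is made from compound 1 by the same change seen between compound 2 and compound 3: methyl in place of hydrogen on an oxygen on an aromatic ring. The place is the same in both pairs, an oxygen on an aromatic ring whose other neighbours are aromatic carbon, so this is the same change carried onto another core.

The step that the limit leaves unreadable from compound 1 to compound 4 is expected to be no more than modest, in line with what the methyl did between compound 2 and compound 3. Because compound 1 already sits at the limit of > 50000 nM in this assay, at which 1 of the 3 values shown sits, a step in the weakening direction would leave compound 4 beyond the reach of this assay as well. Compound 4 is therefore estimated at 100000 nM, with a range from 30000 nM to 400000 nM, and most likely the assay will again report only a limit.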

Compound 4, half-maximal inhibitory concentration: > 50000 nM
Compound 4: no number, only a limit; the forecaster's own chance of this, stated with the estimate: 85%; the middle value lies beyond the limit too.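

Compound 1 and compound 4 both sit at a limit of this assay rather than at a number, so the step from hydroxy to methoxy between them cannot be read: the limit of > 50000 nM in this assay, at which 2 of the 4 values shown sit.

As far as these compounds go, what stays open is how much, if at all, this change moves the number on the core of compound 1, and whether it would match the step seen on the other core (a 2.9-fold higher number from compound 2 to compound 3 (0.47 log units; beyond the scatter)).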